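A few compounds are considered here, and "the series" means these few. Any claim that something is new, unique, unknown or untested is made for them only; others in the source may bear on it.

Measured in a functional assay on MCF7 cells (Homo sapiens) for antiproliferative activity, read by MTT assay, with a stated time of 48 h; a lower number here means a stronger inhibitor, a higher number a weaker inhibitor:
- compound 1 `CC(=O)N1N=C(c2ccc3ccccc3c2)OC1c1ccccc1`: 2.43 ug/mL
- compound 2 `CC(=O)N1N=C(c2ccc3ccccc3c2)OC1c1cccc(Br)c1`: 2.34 ug/mL

Among the compounds with values here, only two numbers exist so far, and compound 2 at 2.34 ug/mL cannot be told apart from compound 1. Compound 3 `CC(=O)N1N=C(c2ccc3ccccc3c2)OC1c1ccc(Br)cc1` has not been measured yet. It holds the same atoms as compound 2, joined differently: 4-bromophenyl in place of 3-bromophenyl on a saturated ring carbon. In short, 4-bromophenyl stands in place of 3-bromophenyl on a saturated ring carbon.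

Within the data shown here, one measured step bears on this: a 1.0-fold lower number from compound 1 to compound 2 (0.02 log units; within the scatter), which is bromo in place of hydrogen on an aromatic carbon. Adding the bromo to compound 1 left the number within the scatter, although no measured compound yet carries 4-bromophenyl. A shift of the bromo is therefore expected to show no step beyond the scatter in this assay.

The expected step is a 1.0-fold lower number from compound 2 to compound 3 (0.01 log units; within the scatter). Compound 3 is estimated at 2.3 ug/mL, with an expected range of 1.2 ug/mL to 4.5 ug/mL.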

Compound 3, half-maximal inhibitory concentration: 5.07 ug/mL
For compound 3 the middle estimate is 2.2-fold (0.34 log units) below the measured one; measured number above the stated range.
By their numbers in this assay, from the lowest: compounds 2 and 1 (each within the scatter of the next); then compound 3.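

In this assay, changing 3-bromophenyl to 4-bromophenyl on the saturated ring carbon gives a 2.2-fold higher number from compound 2 to compound 3 (0.34 log units; beyond the scatter) and makes compound 3 a modestly weaker inhibitor, so the arrangement of the bromo group counts here even though the atoms stay the same. Compared with the plain phenyl group of compound 1, the 4-bromophenyl group gives a 2.1-fold higher number from compound 1 to compound 3 (0.32 log units; beyond the scatter) and shows that adding a bromo can move the number beyond the scatter, which the 3-bromophenyl group of compound 2 did not do. No measurement here explains why the two bromophenyl groups differ.

As far as these compounds go, it remains open whether this step belongs to bromo itself or to any group placed as in 4-bromophenyl. A 4-chlorophenyl or 4-methoxyphenyl group on the same carbon could separate these two readings.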